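Capping the side-chain hydroxyl: from compound 1 to compound 3

The source may hold more compounds than are shown below. What is called first, only, known or untested is meant among the compounds shown, and "the series" means these compounds.

Within the data shown here, compound 1 `COc1nc(C)c(Nc2nc(Cl)cn([C@H](CO)C3CC3)c2=O)cc1C` gives 88 nM in an assay on frontal cortex for displacement of a labelled ligand from corticotropin-releasing factor receptor 1 (Rattus norvegicus), with a stated time of 2 h (on this read-out higher numbers stand for weaker inhibition and lower numbers for stronger inhibition), the highest of the two numbers measured so far. Among the measured compounds shown here, compound 2 `CCCNC(=O)OC[C@H](C1CC1)n1cc(Cl)nc(Nc2cc(C)c(OC)nc2C)c1=O` gives 10 nM in this assay, and the single measured step, an 8.8-fold lower number from compound 1 to compound 2 (0.94 log units; beyond the scatter), puts propylcarbamoyl in place of hydrogen on the oxygen on the saturated carbon; it lies beyond the scatter.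

Compound 3 `COc1nc(C)c(Nc2nc(Cl)cn([C@H](COc3ccc(C(F)(F)F)cn3)C3CC3)c2=O)cc1C` has not yet been measured. It differs from compound 1 by 5-(trifluoromethyl)pyridin-2-yl in place of hydrogen on an oxygen on a saturated carbon. For the measured compounds named here, the change sits on the same oxygen as the one measured step, so that step is the only precedent that bears on it, though what enters here is a six-membered aromatic ring with one hetero atom rather than a carbamate. A step toward stronger inhibition, somewhat smaller than the measured one, is expected because an 8.8-fold lower number from compound 1 to compound 2 (0.94 log units; beyond the scatter) ran that way at this oxygen. Compound 3 is therefore expected to give about 15 nM in this assay, with a likely range of 4 nM to 60 nM. The expected step is a 5.9-fold lower number from compound 1 to compound 3 (0.77 log units; beyond the scatter), an estimate resting on one precedent only.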

Compound 3, half-maximal inhibitory concentration: 1.6 nM
The estimate for compound 3 lay 9.4-fold (0.97 log units) above the measured number, and the stated range ends above it.
By their numbers in this assay, from the lowest: compound 3; then compound 2; then compound 1.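

Working notes on the side-chain oxygen: in this assay, this position accepts an aromatic ring as well as a carbamate, and 5-(trifluoromethyl)pyridin-2-yl gives the larger of the two steps seen from the free hydroxy compound, a 55-fold lower number from compound 1 to compound 3 (1.74 log units; beyond the scatter). Replacing the hydrogen is therefore not the whole story, since the two capped compounds also separate from each other, a 6.3-fold lower number from compound 2 to compound 3 (0.80 log units; beyond the scatter), which shows that the identity of the group on this oxygen matters. Nothing available explains why the pyridinyl ether gives the lowest number of the three.

The compounds shown do not separate the contribution of the pyridine ring from that of its trifluoromethyl group, so the effect of an unsubstituted pyridin-2-yl or a phenyl group on the same oxygen remains open. Also open, going by these compounds, is whether a simple methyl ether would give any of this gain, and whether a longer carbamate chain than propyl would narrow the gap between the carbamate and the pyridinyl ether.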